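Exchanging nitro for amino in a weakly active pair

A few compounds are considered here, and "the series" means these few. Any claim that something is new, unique, unknown or untested is made for them only; others in the source may bear on it.

For the measured compounds named here, in a functional assay on MCF7 cells (Homo sapiens) for antiproliferative activity, read by MTT assay, with stated times of 24 h and 72 h (a lower number here means a stronger inhibitor, a higher number a weaker inhibitor), compound 2 `COc1ccc([C@@H]2[C@H](Oc3ccccc3)C(=O)N2c2cc(OC)c(OC)c(OC)c2)c([N+](=O)[O-])c1O` gives 89000 nM, the higher of the two numbers so far and thus the weaker inhibitor. Going by the values given here, the only other measured member, compound 1 `COc1cc(N2C(=O)[C@@H](Oc3ccccc3)[C@H]2c2ccc(N=[N+]=[N-])cc2)cc(OC)c1OC`, gives 23000 nM. Among the compounds with values here, the single measured step, a 3.9-fold higher number from compound 1 to compound 2 (0.59 log units; beyond the scatter), is modest but beyond the scatter. It replaces the whole group on the saturated ring carbon, so it bears only indirectly on the next change.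

Compound 3 `COc1ccc([C@@H]2[C@H](Oc3ccccc3)C(=O)N2c2cc(OC)c(OC)c(OC)c2)c(N)c1O` keeps the rest of compound 2 and carries amino in place of nitro on an aromatic carbon, ortho to a hydroxy group (amino in place of nitro on an aromatic carbon). Within the data shown here, no measured pair isolates this exchange. Among the measured compounds shown here, with a 3.9-fold higher number from compound 1 to compound 2 (0.59 log units; beyond the scatter) as the only guide to size, a modest move towards a lower number in this assay is expected, although a result within the scatter of compound 2 remains plausible. The expected change is a 2.2-fold lower number from compound 2 to compound 3 (0.35 log units; beyond the scatter). For compound 3 the estimated value is 40000 nM, with an expected range of 13000 nM to 110000 nM.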

Compound 3, half-maximal inhibitory concentration: 19000 nM
The estimate for compound 3 lay 2.1-fold (0.32 log units) above the measured number; measured number inside the range.
By their numbers in this assay, from the lowest: compounds 3 and 1 (each within the scatter of the next); then compound 2.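

In this assay, for the compounds shown here, the pair compound 2 and compound 3 isolates for the first time the exchange at the aromatic carbon ortho to a hydroxy group, and amino in place of nitro gives a 4.7-fold lower number from compound 2 to compound 3 (0.67 log units; beyond the scatter) with the rest of the molecule unchanged. Going by these compounds alone, this aromatic carbon is therefore not indifferent to its substituent in this assay, and the step is larger than the one earlier measured step, which replaced the whole group on the saturated ring carbon. The other new step, a 1.2-fold lower number from compound 1 to compound 3 (0.08 log units; within the scatter), lies within the scatter, so in this assay the group on the saturated ring carbon of compound 3 cannot be told apart from that of compound 1, and the exchange brings compound 3 level with compound 1 rather than past it.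

No measured evidence bears on the origin of the step from nitro to amino and the pair rests on a single exchange at a single position. From the compounds shown here alone, whether an acetamide, a carboxylic acid or plain hydrogen on this aromatic carbon would give a lower or a higher number remains open, as does whether the effect of the exchange depends on the hydroxy group.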